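Amino in place of hydrogen on a fused two-ring core

The compounds below may be only part of what the source reports. "The series", "measured", "known", "first", "only" and "open" are said of these compounds alone.

In a functional assay on K562 cells (Homo sapiens) for cytotoxicity, read by sulforhodamine B assay, with a stated time of 48 h (on this read-out higher numbers stand for lower toxicity in this test and lower numbers for higher toxicity in this test), the measured compounds stand as follows:
compound 1 `ClCc1ccccc1Cn1cnc2c(Cl)nc(Cl)nc21` gives 910 nM;
compound 2 `ClCc1ccccc1Cn1cnc2c(Cl)ncnc21` gives > 100000 nM, a limit ;
compound 3 `ClCc1ccc(Cn2cnc3nc(Cl)nc(Cl)c32)cc1` gives > 100000 nM, a limit.

Compound 2 sits at the limit of > 100000 nM in this assay, at which 2 of the 3 values shown sit, and has no number of its own. Compound 4 `Nc1nc(Cl)c2ncn(Cc3ccccc3CCl)c2n1` differs from it by amino in place of hydrogen on an aromatic carbon. Among the compounds with values here, only one measured step touches this position: an at least 100-fold higher number from compound 1 to compound 2 (2.04 log units; beyond the scatter), a large loss on this read-out. Compound 1, carrying chloro there, gave 910 nM. Compound 2, with hydrogen there, reached only the limit. Within the data shown here, whether an amino group at that position restores what chloro gave, no measured pair shows, so the expectation stays wide. Compound 4 is expected to give 40000 nM, between 5000 nM and 150000 nM. The expected step is an at least 2.5-fold lower number from compound 2 to compound 4 (0.39 log units; beyond the scatter), with a real chance that only a limit is reported.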

Compound 4, concentration lethal to 50% of the cells: > 100000 nM
Compound 4: only a limit was reported; the forecaster's own chance of this, stated with the estimate: 45%; middle value at least 2.5-fold (0.39 log units) from the limit.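

In this assay, amino in place of chloro on the aromatic carbon between two ring nitrogen atoms gives an at least 100-fold higher number from compound 1 to compound 4 (2.04 log units; beyond the scatter). Amino thus joins hydrogen in not keeping what chloro gave, and among the groups shown at this position, only chloro yields a number of its own. The step from hydrogen to amino cannot be read, and compound 4 is itself a limit: the limit of > 100000 nM in this assay, at which 3 of the 4 values shown sit.

Going by these compounds, whether a bromo, methyl or methoxy group at this position would give a number of its own stays open. So does whether a dimethylamino group would behave as amino does.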